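Cytotoxicity notes: aryl exchange on the shared core

The source may report more compounds than this note shows. Statements on the series, on what has been measured and on what is new or still open speak of the compounds shown alone.

For the measured compounds named here, compound 1 `Cn1c(-c2ccc(Br)cc2)cnc1NC(=O)c1ccc(F)cc1` is the one member of this set with a numbered read-out in a toxicity assay on THP-1 cells (Homo sapiens) for inhibition (a higher number here means that more compound is tolerated, a lower number that less compound is tolerated), where compound 1 gives 46000 nM. Compound 2 `COc1ccc(-c2cccc(NC(=O)c3ccc(F)cc3)n2)cc1` reaches only a limit of the same assay, at > 100000 nM. Compound 3 `COc1ccc(-c2cnc(NC(=O)C3CCCCC3)n2C)cc1` carries the same core as compound 1. In this assay compound 3 likewise stops at a limit, at > 100000 nM. Thus compound 1 sits alone below (the limit of > 100000 nM in this assay, at which 2 of the 3 values shown sit), and no step between two numbered values is available for comparison.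

Compound 4 `COc1ccccc1-c1cnc(NC(=O)c2ccc(F)cc2)n1C` is not yet measured. It differs from compound 1 by 2-methoxyphenyl in place of 4-bromophenyl on an aromatic carbon. The change keeps the amide and the methyl-bearing core of compound 1 intact.

With two of three values at a limit, the expected step from compound 1 to compound 4 in this assay is a 2.0-fold higher number from compound 1 to compound 4 (0.29 log units; within the scatter), upward, toward less toxicity, and beyond the scatter in size. The estimate for compound 4 in this assay is 90000 nM, within 35000 nM to 160000 nM, with a real chance that only a limit is reported.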

Compound 4, half-maximal cytotoxic concentration: > 100000 nM
Compound 4 ended at the assay's limit; the forecaster's own chance of this, stated with the estimate: 55%; at least 1.1-fold (0.04 log units) between middle value and limit.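

In this assay, for the compounds shown here, 2-methoxyphenyl in place of 4-bromophenyl on the aromatic carbon of the shared core gives an at least 2.1-fold higher number from compound 1 to compound 4 (0.33 log units; beyond the scatter), the first step in this set that can be read, and it runs toward more compound being tolerated. Going by these compounds, this step is a lower bound, so its full size stays unknown, but it shows that the aryl group at this position alone can move the read-out with the amide and the methyl-bearing core unchanged. Compound 1 remains the only compound with a numbered value, and the rest stand at a limit: the limit of > 100000 nM in this assay, at which 3 of the 4 values shown sit.

The exchange alters both the substituent and where it sits on the phenyl ring, so the loss of bromine and the gain of the 2-methoxy group cannot be told apart. An unsubstituted phenyl, a 4-chlorophenyl or an aminophenyl at this position would help separate the two.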